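Moving the Hydroxyl Along the Chain on the Sulfur

A few compounds are considered here, and "the series" means these few. Any claim that something is new, unique, unknown or untested is made for them only; others in the source may bear on it.

Compound 1 `CC(C)c1n[nH]c2c(NCc3ccc(-c4ccccn4)cc3)nc(SCCCO)nc12` gives 109 nM in a functional assay on HT cells (Homo sapiens) for antiproliferative activity, read by fluorescence, with a stated time of 72 h (on this read-out lower numbers stand for stronger inhibition of growth and higher numbers for weaker inhibition of growth), the lowest of the two numbers in hand; its nearest neighbour, compound 2 `CC(C)c1n[nH]c2c(NCc3ccc(-c4ccccn4)cc3)nc(SC3CCCCC3N)nc12`, gives 139 nM, and the step of a 1.3-fold higher number from compound 1 to compound 2 (0.11 log units; within the scatter) lies within the scatter. Compound 3 `CCC(O)CSc1nc(NCc2ccc(-c3ccccn3)cc2)c2[nH]nc(C(C)C)c2n1` differs from compound 1 by 1-hydroxypropyl in place of 2-hydroxyethyl on a saturated chain carbon bound to a sulfur. Among the measured compounds shown here, the only measured step touching the group on the sulfur exchanged it entirely without moving this assay beyond the scatter, so the shift from 3-hydroxypropyl to 2-hydroxybutyl is expected to do no more. For compound 3 the expected step is a 1.2-fold higher number from compound 1 to compound 3 (0.08 log units; within the scatter), none beyond the scatter. Compound 3 is therefore estimated at 130 nM, between 55 nM and 310 nM.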

Compound 3, concentration for 50% growth inhibition: 273 nM
Beside the measured number, compound 3's estimate is 2.1-fold (0.32 log units) below it; the measured number falls inside the stated range.
By their numbers in this assay, from the lowest: compounds 1, 2 and 3 (each within the scatter of the next, the first and the last beyond it).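

In this assay, among the compounds shown here, the change from 3-hydroxypropyl to 2-hydroxybutyl gives a 2.5-fold higher number from compound 1 to compound 3 (0.40 log units; beyond the scatter) and is the first step on the sulfur to pass the scatter, so a small change within this chain can register here. The step of a 2.0-fold higher number from compound 2 to compound 3 (0.29 log units; within the scatter) still stays inside the scatter, so compound 2 and compound 3 are not told apart. Nothing measured here gives a reason for the step from compound 1.

The compounds shown do not separate the added carbon from the moved hydroxyl, which 2-hydroxypropyl on the sulfur would do. Going by these compounds, whether a carboxylic acid or a longer chain carrying the hydroxyl would be tolerated also stays open.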